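This account rests on a few compounds, and the source may have more. Where it says the series, first, only, none or still open, it means among the compounds named here.

Measured in a functional assay on MDA-MB-231 cells (Homo sapiens) for antiproliferative activity, read by MTT assay, with a stated time of 72 h; a lower number here means a stronger inhibitor, a higher number a weaker inhibitor:
- compound 1 `CC(Nc1ncnc2ncc(-c3cnn(C4CCNCC4)c3)cc12)c1c(Cl)ccc(F)c1Cl`: 7110 nM
- compound 2 `CC(Nc1nc(N)nc2ccc(-c3cnn(C)c3)cc12)c1c(Cl)ccc(F)c1Cl`: 7960 nM

Compound 1 stands level with compound 2, as the two values lie within the scatter of each other. Both sit in the same range, and neither stands apart.

The next compound to read is compound 3 `CC(Nc1ncnc2ncc(-c3cnn(C)c3)cc12)c1c(Cl)ccc(F)c1Cl`. Relative to compound 1, it carries methyl in place of piperidin-4-yl on an aromatic nitrogen of a five-membered aromatic ring with 2 nitrogen: methyl in place of piperidin-4-yl on an aromatic nitrogen.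

Within the data shown here, no measured pair shows this change on its own, so the data give no direct step to carry over. Among the measured compounds shown here, the only guide is the range set by compound 1 at 7110 nM. The expected change in this assay is none beyond the scatter, and the estimated step is a 1.2-fold higher number from compound 1 to compound 3 (0.08 log units; within the scatter). For compound 3 the estimated value is 8500 nM, with an expected range of 3000 nM to 24000 nM.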

Compound 3, half-maximal inhibitory concentration: > 100000 nM
Compound 3 gave a limit, no number; the forecaster's own chance of this, stated with the estimate: 20%; at least 11-fold (1.07 log units) between middle value and limit.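

In this assay, methyl in place of piperidin-4-yl on an aromatic nitrogen of the five-membered ring gives an at least 14-fold higher number from compound 1 to compound 3 (1.14 log units; beyond the scatter). The value of compound 3 is a limit of the assay and not a number: the limit of > 100000 nM in this assay, at which 1 of the 3 values shown sits. On the core of compound 1, then, the group on this nitrogen is not a neutral substituent, and the measurable antiproliferative activity of compound 1 does not survive the change to methyl.

The compounds shown do not tell whether the difference follows the ring of piperidin-4-yl or its nitrogen, nor how small the group can become before the activity is lost. A cyclohexyl ring, which has no ring nitrogen, and an open aminoethyl chain, which keeps an amine without the ring, would separate these two readings on the same aromatic nitrogen.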